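The source may hold more compounds than are shown below. What is called first, only, known or untested is meant among the compounds shown, and "the series" means these compounds.

Working notes on the ester series in a functional assay on PC-3 cells (Homo sapiens) for antiproliferative activity, read by sulforhodamine B assay, with a stated time of 48 h, tested at 50 uM; a higher number here means more inhibition at the concentration tested (going by the name of the read-out), a lower number less inhibition.

Compound 1 `CC1=CC[C@H](C(C)C)c2cc(C)c(OC(=O)c3ccc(C)cc3)cc21` gives 49.6% in this assay. Of the three compounds measured, compound 1 stands second highest: compound 2 `Cc1cc2c(C(C)C)ccc(C)c2cc1OC(=O)c1cccc(C(F)(F)F)c1` gives 26.7%, a number beyond the scatter lower, while compound 3 `Cc1cc2c(C(C)C)ccc(C)c2cc1OC(=O)c1ccc(C(F)(F)F)cc1` gives 100%, beyond the scatter higher and the furthest from compound 1. Going by the values given here, compounds 2 and 3 share a core that differs from the core of compound 1, so no single-point step between measured compounds is available here.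

Compound 4 `CC1=CC[C@H](C(C)C)c2cc(C)c(OC(=O)c3cccc(C)c3)cc21` is not yet measured. It differs from compound 1 in one place: 3-methylphenyl in place of 4-methylphenyl on a carbonyl carbon. Compounds 2 and 3 carry the same trifluoromethyl group on differently substituted benzoate rings and their values lie far apart, which suggests that the placement of a single group on the ester ring can matter in this assay. The step from compound 1 to compound 4 is expected to be a moderate decrease, a number 14.6 percentage points lower from compound 1 to compound 4 (beyond the scatter). Compound 4 is estimated at 35%, within 15% to 60%.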

Compound 4, a percentage reported as inhibition, at one concentration (the size of the read-out at that concentration, not a potency): 38.6%
Estimate against measurement, compound 4: 3.6 percentage points below, within the range that was stated.
By their numbers in this assay, from the lowest: compound 2; then compound 4; then compound 1; then compound 3.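

In this assay, going by these compounds alone, the change from 4-methylphenyl to 3-methylphenyl on a carbonyl carbon gives a number 11 percentage points lower from compound 1 to compound 4 (beyond the scatter) and is the first step that can be read at a single place. The two compounds hold the same atoms joined differently, so moving the methyl group on the ester ring is enough on its own to shift the read-out, though only modestly. Nothing at hand bears on the reason for this shift.

Left open is how a carboxylic acid or an amine on the ester ring would read on the core of compound 1. Also open, from the compounds shown here alone, is whether a step of this size between the two ring placements carries over to the core shared by compound 2 and compound 3.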